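The source may report more compounds than this note shows. Statements on the series, on what has been measured and on what is new or still open speak of the compounds shown alone.

In an ADME assay (liver) for metabolic stability, with Liver microsome (Homo sapiens) as the target, using microsomes and NADPH, with a stated time of 30 min, tested at 1 uM (a higher number here means faster removal of the compound, a lower number slower removal), compound 1 `CC(C)(C)n1cc(-c2cc(C(O)(C(F)(F)F)C(F)(F)F)cnc2N2CCN(S(=O)(=O)c3ccc(N)nc3)CC2)cn1` gives 86 mL.min-1.g-1. For the measured compounds named here, compound 2 `Nc1ccc(S(=O)(=O)N2CCN(c3ncc(C(O)(C(F)(F)F)C(F)(F)F)cc3-c3ccccc3O)CC2)cn1` gives 22 mL.min-1.g-1, the lowest of the two numbers so far. Compound 3 `NC(=O)c1cccc(-c2cc(C(O)(C(F)(F)F)C(F)(F)F)cnc2N2CCN(S(=O)(=O)c3ccc(N)nc3)CC2)c1` has yet to be measured and differs from compound 2 at one place, with 3-carbamoylphenyl in place of 2-hydroxyphenyl on an aromatic carbon. Going by the values given here, one measured step bears on this change, and it is modest: a 3.9-fold lower number from compound 1 to compound 2 (0.59 log units; beyond the scatter), with 2-hydroxyphenyl in place of 1-(tert-butyl)-1H-pyrazol-4-yl on that same carbon. Among the compounds with values here, no compound carrying 3-carbamoylphenyl has been measured, so that step is only a loose guide. In the new change, the leaving and the entering group each hold one six-membered aromatic ring of carbon only. No step beyond the scatter is therefore expected in this assay, in either direction. The expected change is a 1.1-fold lower number from compound 2 to compound 3 (0.04 log units; within the scatter). For compound 3 the estimate is 20 mL.min-1.g-1, with an expected range from 9 mL.min-1.g-1 to 48 mL.min-1.g-1.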

Compound 3, intrinsic clearance in microsomes: 17 mL.min-1.g-1
Beside the measured number, compound 3's estimate is 1.2-fold (0.07 log units) above it; the measured number falls inside the stated range.
By their numbers in this assay, from the lowest: compounds 3 and 2 (each within the scatter of the next); then compound 1.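

In this assay, two different substituted phenyl groups can occupy this aromatic carbon, ortho to a large group, with the step between them within the scatter: a 1.3-fold lower number from compound 2 to compound 3 (0.11 log units; within the scatter). Compound 3 also gives a 5.1-fold lower number from compound 1 to compound 3 (0.70 log units; beyond the scatter), so the earlier step away from 1-(tert-butyl)-1H-pyrazol-4-yl is not confined to 2-hydroxyphenyl, and both entering groups, each with one six-membered aromatic ring of carbon only, stand beyond the scatter from compound 1. No measurement available here accounts for these steps.

The compounds shown leave open whether the difference from compound 1 follows the tert-butyl group or the pyrazole ring, which a 1H-pyrazol-4-yl group without tert-butyl or an unsubstituted phenyl at this carbon would help to separate. They also leave open how a carboxylic acid in place of the carbamoyl group would read in this assay.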